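This account rests on a few compounds, and the source may have more. Where it says the series, first, only, none or still open, it means among the compounds named here.

In a functional assay on the whole organism (Hindlimb, strain albino) with Mus musculus as the target, in the maximal electroshock model, with a stated time of 0.5 h (a lower number here means that less compound is needed, a higher number that more compound is needed for the effect), compound 1 `CC(=O)N1N=C(Nc2nc3ccccc3s2)CC1c1ccccc1` gives 315 umol/kg, compound 3 `CC(=O)N1N=C(Nc2nc3ccccc3s2)CC1OC1=CC=C1` gives 382 umol/kg and compound 2 `COc1ccc(C2CC(Nc3nc4ccc([N+](=O)[O-])cc4s3)=NN2C(C)=O)cc1O` gives 178 umol/kg. Compound 3 thus stands level with compound 1 within the scatter, and its number is higher than that of compound 2. Compound 4 `COc1ccc(C2CC(Nc3nc4ccccc4s3)=NN2C(C)=O)cc1O` keeps the core of compound 3 and changes one group: a group of 9 heavy atoms (7 carbon, 2 oxygen; one six-membered aromatic ring of carbon only) in place of a group of 5 heavy atoms (4 carbon, 1 oxygen; one four-membered non-aromatic ring of carbon only), on a saturated ring carbon. The entering 3-hydroxy-4-methoxyphenyl group already appears in compound 2, which has a different core. Within the data shown here, the only measured step on this saturated ring carbon is a 1.2-fold higher number from compound 1 to compound 3 (0.08 log units; within the scatter), so the one exchange seen there left the number within the scatter. Among the measured compounds shown here, no measured step isolates the 3-hydroxy-4-methoxyphenyl group. The value of compound 2 nevertheless points towards a lower number, so a modest fall, not beyond the scatter, is expected in this assay. The expected change is a 1.5-fold lower number from compound 3 to compound 4 (0.18 log units; within the scatter). For compound 4 the estimated value is 250 umol/kg, with an expected range from 125 umol/kg to 480 umol/kg.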

Compound 4, dose for half-maximal effect: 259 umol/kg
Compound 4: the middle estimate sits 1.0-fold (0.02 log units) below what was measured; low and high end bracket the measured number.
By their numbers in this assay, from the lowest: compounds 2, 4, 1 and 3 (each within the scatter of the next, the first and the last beyond it).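

In this assay the saturated ring carbon now carries three different groups on the shared core, and the steps among them stay within the scatter: a 1.2-fold lower number from compound 1 to compound 4 (0.09 log units; within the scatter) for 3-hydroxy-4-methoxyphenyl in place of phenyl, and a 1.5-fold lower number from compound 3 to compound 4 (0.17 log units; within the scatter) for the same group in place of the four-membered ring group. Adding the hydroxy and methoxy groups to the phenyl ring therefore did not take the number beyond the scatter. Among these compounds, the first measured step on an aromatic carbon, a 1.5-fold higher number from compound 2 to compound 4 (0.16 log units; within the scatter) for hydrogen in place of nitro, also stays within the scatter. No measured evidence bears on the cause of these results. The compounds shown leave open whether an amine or a carboxylic acid on this saturated ring carbon would take the number beyond the scatter.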